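This account rests on a few compounds, and the source may have more. Where it says the series, first, only, none or still open, it means among the compounds named here.

Within the data shown here, compound 1 `COc1cc(/C=C/C(=O)c2cccc(-n3cc(-c4ccc(C)cc4)nn3)c2)ccc1O` in a functional assay on RAW264.7 cells (Mus musculus) for inhibition, with a stated time of 4 days (on this read-out higher numbers stand for weaker inhibition and lower numbers for stronger inhibition), gives 15400 nM, the highest of the two numbers so far; compound 2 `CCCCCc1ccc(-c2cn(-c3cccc(C(=O)/C=C/c4ccc(O)c(OC)c4)c3)nn2)cc1` gives 5780 nM, a 2.7-fold lower number from compound 1 to compound 2 (0.43 log units; beyond the scatter). Compound 3 `COc1cc(/C=C/C(=O)c2cccc(-n3cc(-c4ccc(Br)cc4)nn3)c2)ccc1O` differs from compound 1 by bromo in place of methyl on an aromatic carbon. Among the measured compounds shown here, the only measured step sits at the same place, on an aromatic carbon of the six-membered aromatic ring of carbon only, but it is a different change, butyl in place of hydrogen on a saturated chain carbon bound to an aromatic carbon, and gives no direction for bromo in place of methyl. No step beyond the scatter is expected; the estimated step is a 1.3-fold lower number from compound 1 to compound 3 (0.11 log units; within the scatter). For compound 3 the expected value in this assay is 12000 nM, within 5000 nM to 30000 nM.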

Compound 3, half-maximal inhibitory concentration: 19100 nM
For compound 3 the middle estimate is 1.6-fold (0.20 log units) below the measured one; low and high end bracket the measured number.
By their numbers in this assay, from the lowest: compound 2; then compounds 1 and 3 (each within the scatter of the next).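

In this assay, bromo in place of methyl on this aromatic carbon gives a 1.2-fold higher number from compound 1 to compound 3 (0.09 log units; within the scatter), so the two small groups cannot be told apart here. The pentyl group remains the only one that separates, with a 3.3-fold higher number from compound 2 to compound 3 (0.52 log units; beyond the scatter), so the position does respond to some changes. No supporting data bear on why these groups compare as they do.

On these data alone, whether a chain longer than pentyl would lower the number further remains open. So does the effect of an amine or a carboxylic acid at this position.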